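The compounds below may be only part of what the source reports. "The series", "measured", "known", "first", "only" and "open" are said of these compounds alone.

Compound 1, `CCC/N=C(/NC#N)NCCCCn1nc(-c2ccccc2)ccc1=O`, gives > 100 mg/kg in a functional assay on the whole organism (stomach) with Rattus norvegicus as the target (a higher number here means that more compound is needed for the effect, a lower number that less compound is needed), which is a limit of the assay rather than a number. Compound 2, `N#CNC(=N)NCCCCn1nc(-c2ccccc2)ccc1=O`, gives 77.2 mg/kg in this assay. Compound 3, `CC(C)C/N=C(\S)NCCCCn1nc(-c2ccccc2)ccc1=O`, gives > 100 mg/kg in this assay, again a limit of the assay.

Within the data shown here, compound 2 therefore stands alone as the only measured number among the three; the other two sit at the limit of > 100 mg/kg in this assay, at which 2 of the 3 values shown sit. The steps around it are only partly readable: an at least 1.2-fold lower number from compound 1 to compound 2 (0.11 log units; that floor lies within the scatter), an at least 1.2-fold higher number from compound 2 to compound 3 (0.11 log units; that floor lies within the scatter), and a step that the two limits leave unreadable from compound 1 to compound 3. All three steps change a group on an amine nitrogen.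

Compound 4, `CN(C)/C(=N/CCCn1nc(-c2ccccc2)ccc1=O)NC#N`, differs from compound 2 elsewhere: a group of 8 heavy atoms (4 carbon, 4 nitrogen; no ring) in place of a group of 7 heavy atoms (3 carbon, 4 nitrogen; no ring), on a saturated chain carbon, three bonds along the chain from an aromatic nitrogen. Among the measured compounds shown here, no measured step touches that place, so the three steps above bear on it only by showing that all compounds of this core so far lie at or near the same dose level. Compound 4 is expected to give a number near that of compound 2, with no step beyond the usual scatter: a 1.1-fold lower number from compound 2 to compound 4 (0.04 log units; within the scatter). The estimate for compound 4 is 70 mg/kg, with a range from 25 mg/kg to 200 mg/kg.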

Compound 4, dose for half-maximal effect: 53 mg/kg
Estimate against measurement, compound 4: 1.3-fold (0.12 log units) above; low and high end bracket the measured number.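

Among these compounds, compound 4 gives the first step at this place, on a saturated chain carbon, three bonds along the chain from an aromatic nitrogen, and the first step in this assay with a true number at both ends, since the earlier readable steps each had a limit at one end. The step is a 1.5-fold lower number from compound 2 to compound 4 (0.16 log units; within the scatter), so the two compounds cannot be told apart in this assay. This holds even though the group with 8 heavy atoms and 1 hydrogen-bond donor replaces the group with 7 heavy atoms and 3 hydrogen-bond donors, so this one exchange, taken as a whole, leaves the dose within the usual scatter.

From the compounds shown here alone, since size and donor count change together in this single step, their separate contributions stay unknown, and so does the outcome with a quite different group at this place, such as a carboxylic acid, an amine or a longer chain. The shared core also has no firm ranking yet, because compound 1 and compound 3 are limits of the assay and give no number to compare: the limit of > 100 mg/kg in this assay, at which 2 of the 4 values shown sit.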